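Ether to Sulfide: From Compound 1 to Compound 4

A few compounds are considered here, and "the series" means these few. Any claim that something is new, unique, unknown or untested is made for them only; others in the source may bear on it.

Compound 1 `Nc1cc(N)c2nc(-c3ccccc3)c(Oc3ccc(Cl)c(Cl)c3)nc2c1` was examined in a functional assay on SF-268 cells (Homo sapiens) for inhibition, read by sulforhodamine B assay, with a stated time of 48 h; on this read-out lower numbers stand for higher toxicity in this test and higher numbers for lower toxicity in this test. In that test compound 1 gives < 100000 nM, which is a limit of the assay and not a number. Two related compounds stand at the same point. Compound 2 `CCOC(=O)[C@H](CCC(=O)O)NC(=O)c1ccc(Sc2nc3cc(N)cc(N)c3nc2-c2ccccc2)cc1` gives < 100000 nM in this assay, again a limit. Compound 3 `CCOC(=O)[C@H](CCC(=O)O)NC(=O)c1ccc(Oc2nc3cc(N)cc(N)c3nc2-c2ccccc2)cc1` gives < 100000 nM in this assay, also a limit. Taken together the three results share (the limit of < 100000 nM in this assay, at which 3 of the 3 values shown sit), so compound 1 cannot be placed above or below either companion; all that is known is that each of them sits at the limit.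

Compound 4 `Nc1cc(N)c2nc(-c3ccccc3)c(Sc3ccc(F)cc3)nc2c1` has not yet been measured in this assay. It differs from compound 1 by (4-fluorophenyl)sulfanyl in place of 3,4-dichlorophenoxy on an aromatic carbon. Within the data shown here, no step between measured compounds is available to guide the size of this change. Every measured result stops at the limit. With nothing pointing toward a larger or a smaller number, the step expected in this assay is a step that the limit leaves unreadable from compound 1 to compound 4, that is, none beyond the usual scatter. On that basis compound 4 is estimated at 30000 nM, with a plausible range from 5000 nM to 100000 nM, and a real chance that the assay will again return only a limit.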

Compound 4, concentration lethal to 50% of the cells: 85100 nM
Compound 4: middle estimate off by 2.8-fold (0.45 log units), on the low side; low and high end bracket the measured number.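

In this assay compound 1 gives < 100000 nM which is a limit and not a number. Among these compounds, compound 4 gives 85100 nM as a number, yet no step from compound 1 to compound 4 can be read: (the limit of < 100000 nM in this assay, at which 3 of the 4 values shown sit). The compounds shown leave open how far (4-fluorophenyl)sulfanyl in place of 3,4-dichlorophenoxy moves the result.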